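The source may hold more compounds than are shown below. What is called first, only, known or untested is meant among the compounds shown, and "the series" means these compounds.

Compound 1 `NCc1cn(-c2ccccc2)nn1` is the starting point here. Going by the values given here, in an assay on isolated protein for inhibition of Amine oxidase [flavin-containing] B (Homo sapiens), read by fluorescence (on this read-out higher numbers stand for weaker inhibition and lower numbers for stronger inhibition), compound 1 gives 511000 nM, the highest of the two numbers measured so far, so it is the weakest inhibitor among the measured pair. Among the compounds with values here, its only measured neighbour is compound 2 `NCc1cn(-c2cccc(C(=O)O)c2)nn1`, which in this assay gives 62100 nM; the step of an 8.2-fold lower number from compound 1 to compound 2 (0.92 log units; beyond the scatter) shows what adding the same kind of group to another spot on the ring did.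

Compound 3 `NCc1cn(-c2ccc(C(=O)O)cc2)nn1` has not yet been measured. It differs from compound 1 in this way: carboxy in place of hydrogen on an aromatic carbon.

Within the data shown here, the step from compound 1 to compound 2 is the only measured change that bears on this question, because an 8.2-fold lower number from compound 1 to compound 2 (0.92 log units; beyond the scatter) involved the same group entering the same ring, only at a different place. On that basis a step of similar size and in the same direction, towards a lower number, is expected for compound 3, though with wide uncertainty as the placement is new. The expected step is a 6.4-fold lower number from compound 1 to compound 3 (0.81 log units; beyond the scatter). Compound 3 is therefore estimated to give 80000 nM in this assay, with a likely range from 20000 nM to 320000 nM.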

Compound 3, half-maximal inhibitory concentration: 56900 nM
Compound 3: the middle estimate sits 1.4-fold (0.15 log units) above what was measured, within the range that was stated.
By their numbers in this assay, from the lowest: compounds 3 and 2 (each within the scatter of the next); then compound 1.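

In this assay, the carboxy group also lowers the number when it sits on the aromatic carbon para to a group of 7 heavy atoms, giving a 9.0-fold lower number from compound 1 to compound 3 (0.95 log units; beyond the scatter). Compound 2 at 62100 nM and compound 3 at 56900 nM lie within the scatter of each other, so these two compounds show no readable difference between the two placements, and the lower number is not tied to a single spot on the ring. Nothing measured here explains why adding the group has this effect.

The compounds shown leave open whether the acidic hydrogen of the carboxylic acid matters, which a methyl ester or a primary amide at the same place could test, and whether a hydroxyl group or a nitrile would lower the number in a similar way. They also leave open whether a longer chain between the ring and the carboxylic acid would keep, deepen or lose the step seen here.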